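This account rests on a few compounds, and the source may have more. Where it says the series, first, only, none or still open, it means among the compounds named here.

Compound 1, with the structure `C=C1C(=O)O[C@]2(C)CC[C@@H]1C[C@H](O)[C@@]1(C)CC[C@H](OC(C)=O)[C@@](C)(CCC2=O)O1`, and compound 2, with the structure `C=C1C(=O)O[C@]2(C)CC[C@@H]1C[C@H](O)[C@@]1(C)CC[C@H](O1)[C@](C)(O)CC[C@H]2OC(C)=O`, share a core carrying a hydroxy group. In a functional assay on Doay cells (Homo sapiens) for cytotoxicity (on this read-out lower numbers stand for stronger inhibition and higher numbers for weaker inhibition), compound 1 gives only a limit of > 20 ug/mL, not a number. Compound 2 likewise gives only a limit in this assay, > 20 ug/mL; both values sit at the same limit, as the limit of > 20 ug/mL in this assay, at which 2 of the 2 values shown sit, shows. Compound 3, with the structure `C=C1C(=O)O[C@]2(C)CC[C@@H]1C[C@H](OC(C)=O)[C@@]1(C)CC[C@H](O1)[C@](C)(O)CC[C@H]2OC(C)=O`, differs from compound 2 by acetyl in place of hydrogen on an oxygen on a saturated carbon. For the measured compounds named here, with no measured step between compounds available, the expected step from compound 2 to compound 3 is a step that the limit leaves unreadable from compound 2 to compound 3, no change beyond the scatter. Compound 3 is therefore estimated at 30 ug/mL, in the range 12 ug/mL to 80 ug/mL.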

Compound 3, half-maximal inhibitory concentration: > 20 ug/mL
Compound 3: a limit, no number; the forecaster's own chance of this, stated with the estimate: 70%; the middle value does not contradict the limit.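

Compound 2 and compound 3 both give only a limit in this assay, so no step can be read between them: the limit of > 20 ug/mL in this assay, at which 3 of the 3 values shown sit. The compounds shown leave open whether hydroxy to acetoxy changes cytotoxicity at all.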